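Chloro in place of methyl on the shared core

The source may report more compounds than this note shows. Statements on the series, on what has been measured and on what is new or still open speak of the compounds shown alone.

In an ADME assay on microsomes from liver (Homo sapiens) for metabolic stability, read by LC-MS, with a stated time of 30 min, tested at 1 uM (a lower number here means that less of the compound is left, a higher number that more of the compound is left), compound 1 `CC(C)(C)NCc1cc(Cl)cc(Nc2nc3ccccc3n2Cc2ccc(C(F)(F)F)cc2)c1O` gives 81% and compound 2 `CCNCc1cc(C)cc(Nc2nc3ccccc3n2Cc2ccc(C(F)(F)F)cc2)c1O` gives 98%. Compound 2 is the higher of the two, and the gap lies beyond the scatter. Compound 3 `CCNCc1cc(Cl)cc(Nc2nc3ccccc3n2Cc2ccc(C(F)(F)F)cc2)c1O` follows from compound 2 by putting chloro in place of methyl on an aromatic carbon, para to a hydroxy group (chloro in place of methyl on an aromatic carbon). Among the compounds with values here, no measured pair isolates this change, and compound 1 differs from compound 3 at a second place as well as sharing its chloro. The evidence for the direction is therefore thin. A modest fall is expected, since compound 3 shares the chloro group with compound 1, which gives 81%. The estimated change is a number 10 percentage points lower from compound 2 to compound 3 (within the scatter), a step that may stay within the scatter. For compound 3 the estimated value is 88%, with an expected range of 74% to 98%.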

Compound 3, percent of the compound remaining: 94%
Beside the measured number, compound 3's estimate is 6 percentage points below it; the measured number falls inside the stated range.
By their numbers in this assay, from the lowest: compound 1; then compounds 3 and 2 (each within the scatter of the next).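

In this assay, chloro in place of methyl on the aromatic carbon para to a hydroxy group now has a pair of its own, and the step is a number 4 percentage points lower from compound 2 to compound 3 (within the scatter); at this position the read-out does not separate the two groups. Within the data shown here, the same compound gives the first one-place reading at the amine nitrogen, where ethyl in place of tert-butyl gives a number 13 percentage points higher from compound 1 to compound 3 (beyond the scatter), so in these compounds the step beyond the scatter lies at the nitrogen and not at the aromatic carbon. Nothing measured here bears on the reason for either step.

From the compounds shown here alone, each place rests on a single step, so it remains open how isopropyl or cyclopropyl on the amine nitrogen would read. Also open, going by these compounds, is how fluoro or nitrile on the aromatic carbon would read, and whether the methyl to chloro step holds with tert-butyl on the nitrogen.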